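Pyrrolidin-1-yl in place of diethylamino on a side chain

The source may report more compounds than this note shows. Statements on the series, on what has been measured and on what is new or still open speak of the compounds shown alone.

Measured in a functional assay on A549 cells (Homo sapiens) for antiproliferative activity, read by MTT assay, with a stated time of 72 h; on this read-out higher numbers stand for weaker inhibition and lower numbers for stronger inhibition:
- compound 1 `COc1cc(/C=N/NC(=O)Nc2ccc(Oc3ccnc4[nH]ccc34)c(F)c2)cc(OC)c1OC`: 34100 nM
- compound 2 `O=C(N/N=C/c1ccccc1)Nc1ccc(Oc2ccnc3[nH]ccc23)cc1`: 17200 nM
- compound 3 `CCN(CC)CCCn1cccc1/C=N/NC(=O)Nc1ccc(Oc2ccnc3[nH]ccc23)c(F)c1`: 1210 nM

Compound 3 stands lowest of the three at 1210 nM, and its gaps to compound 2 and to compound 1 both lie beyond the usual scatter. These three compounds differ from one another in more than one place, so no single structural change can be read from their numbers. Within the data shown here, no measured pair shows the swap considered here either.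

Compound 4 `O=C(N/N=C/c1cccn1CCCN1CCCC1)Nc1ccc(Oc2ccnc3[nH]ccc23)c(F)c1` matches compound 3 except for one group: pyrrolidin-1-yl in place of diethylamino on a saturated chain carbon, three bonds along the chain from an aromatic nitrogen. Everything else stays as in compound 3, which gives 1210 nM, so that value is the natural starting point for a forecast.

In this assay the estimated step of a 1.1-fold lower number from compound 3 to compound 4 (0.04 log units; within the scatter) is expected to stay within the usual scatter, with no firm direction. For compound 4 the expected value is 1100 nM, with an estimated range from 450 nM to 2800 nM.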

Compound 4, half-maximal inhibitory concentration: 2010 nM
The estimate for compound 4 lay 1.8-fold (0.26 log units) below the measured number, within the range that was stated.
By their numbers in this assay, from the lowest: compounds 3 and 4 (each within the scatter of the next); then compounds 2 and 1 (each within the scatter of the next).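

In this assay, the swap gives a 1.7-fold higher number from compound 3 to compound 4 (0.22 log units; within the scatter). Among these compounds, this is the first comparison in the set that changes only one place, and it shows that the diethylamino group at the end of the 3-(diethylamino)propyl chain can be exchanged for pyrrolidin-1-yl with no difference that stands out from repeat measurements, even though the open group has no ring and the new one does. Nothing measured here explains why the two compounds read alike.

The compounds shown leave open whether other amines at the same place, such as dimethylamino, piperidin-1-yl or morpholin-4-yl, would also fit this picture, and whether it would hold on a shorter chain such as 2-(pyrrolidin-1-yl)ethyl. Compound 1 and compound 2 differ from compound 3 in more than one place, so the contribution of the amine-bearing chain as a whole also remains unresolved, and a version with a plain propyl chain lacking the amine would be needed to isolate it.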